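This account rests on a few compounds, and the source may have more. Where it says the series, first, only, none or still open, it means among the compounds named here.

Compound 1 `N#Cc1cc(NS(=O)(=O)c2ccc(NC(=O)N3CCOCC3)cc2)ccc1Oc1ccc(Cl)c(C(F)(F)F)c1`: 27%
Compound 2 `CC(=O)NCc1ccc(S(=O)(=O)Nc2ccc(Oc3ccc(Cl)c(C(F)(F)F)c3)c(C#N)c2)cc1`: 51%
Compound 3 `CC(=O)N(C)c1ccc(S(=O)(=O)Nc2ccc(Oc3ccc(Cl)c(C(F)(F)F)c3)c(C#N)c2)cc1`: not yet measured

Among the compounds with values here, in an assay for inhibition of platelet-activating factor acetylhydrolase (Rattus norvegicus), in plasma, with stated times of 30 min and 10 min, tested at 50 nM (on this read-out higher numbers stand for more inhibition at the one concentration tested (going by the name of the read-out) and lower numbers for less inhibition), compound 1 gives 27%, the lowest of the two numbers measured so far. Compound 2 gives 51%, and the step of a number 24 percentage points higher from compound 1 to compound 2 (beyond the scatter) lies beyond the scatter. Compound 3 differs from compound 1 by acetyl(methyl)amino in place of ((morpholin-4-yl)carbonyl)amino on an aromatic carbon. Within the data shown here, only one measured step bears on this: the step of a number 24 percentage points higher from compound 1 to compound 2 (beyond the scatter), in which the same group leaves the same position and a short group without a ring enters in its place. That step was modest and upward, and the change to compound 3 removes the same ring-bearing group, so a step of comparable kind is expected, though the entering group is not the same and the analogy is loose. Compound 3 is therefore expected to show a number 18 percentage points higher from compound 1 to compound 3 (beyond the scatter). Among the measured compounds shown here, the estimate for compound 3 in this assay is 45%, with a range from 25% to 65%, wide because only the single step of a number 24 percentage points higher from compound 1 to compound 2 (beyond the scatter) supports it.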

Compound 3, a percentage reported as inhibition, at one concentration (the size of the read-out at that concentration, not a potency): 15%
Compound 3: middle estimate off by 30 percentage points, on the high side; the whole stated range lies above it.
By their numbers in this assay, from the lowest: compound 3; then compound 1; then compound 2.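

Taking away the ((morpholin-4-yl)carbonyl)amino group does not by itself raise the number in this assay: acetamidomethyl in its place moved the result upward (the step: a number 24 percentage points higher from compound 1 to compound 2 (beyond the scatter)), whereas acetyl(methyl)amino moves it downward (the step: a number 12 percentage points lower from compound 1 to compound 3 (beyond the scatter)). The two entering groups have no ring and sit on the same aromatic carbon, para to a large group, yet exchanging one for the other gives the largest change seen so far (the step: a number 36 percentage points lower from compound 2 to compound 3 (beyond the scatter)), so among these three compounds the result depends on which short group enters and not merely on the loss of the ring. Nothing available here explains why these two groups differ so much.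

The compounds shown leave open which feature separating acetamidomethyl from acetyl(methyl)amino matters, and the plain acetylamino group would be a useful comparison with both. They also leave open how this position would respond to quite different groups, such as an aminomethyl group, a carboxylic acid or a longer amide chain.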